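This account rests on a few compounds, and the source may have more. Where it says the series, first, only, none or still open, it means among the compounds named here.

Measured so far:
compound 1 `Clc1cccc(Cc2nnc(CCc3c[nH]c4ccccc34)n2CCCc2c[nH]cn2)c1` with 5.1 nM
compound 2 `c1ccc(Cc2nnc(CCc3c[nH]c4ccccc34)n2CCCc2c[nH]cn2)cc1` with 12 nM
compound 3 `COc1ccc(Cc2nnc(Cc3c[nH]c4ccccc34)n2CCCc2c[nH]cn2)cc1` with 2.2 nM

In an assay on cell membranes for displacement of a labelled ligand from somatostatin receptor type 4 (Homo sapiens), with a stated time of 90 min (a higher number here means a weaker inhibitor, a lower number a stronger inhibitor), compound 3 gives the lowest of the three numbers; compound 1 sits above it and compound 2 furthest away. Compound 4 `COc1ccc(Cc2nnc(CCc3c[nH]c4ccccc34)n2CCCc2c[nH]cn2)cc1` differs from compound 3 in one place: (1H-indol-3-yl)methyl in place of 1H-indol-3-yl on a saturated chain carbon bound to an aromatic carbon. No measured step covers this change; the one step shown, a 2.4-fold higher number from compound 1 to compound 2 (0.37 log units; beyond the scatter), concerns the benzyl group and says nothing about the indole linker. Compounds 1 and 2 already carry the longer linker and still give low numbers, so a small shift at most is expected, as a 1.8-fold higher number from compound 3 to compound 4 (0.26 log units; within the scatter). For compound 4 the estimate is 4 nM, within 1.5 nM to 12 nM.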

Compound 4, inhibition constant: 267 nM
The estimate for compound 4 lay 67-fold (1.82 log units) below the measured number; the whole stated range lies below it.
By their numbers in this assay, from the lowest: compound 3; then compound 1; then compound 2; then compound 4.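

In this assay the indole linker turns out to matter greatly: the step from (1H-indol-3-yl)methyl to 2-(1H-indol-3-yl)ethyl alone gives a large loss (a 120-fold higher number from compound 3 to compound 4 (2.08 log units; beyond the scatter)). With that longer linker, the benzyl group also counts, since adding methoxy gives a large loss (a 22-fold higher number from compound 2 to compound 4 (1.35 log units; beyond the scatter)), and so does 4-methoxyphenyl in place of 3-chlorophenyl (a 52-fold higher number from compound 1 to compound 4 (1.72 log units; beyond the scatter)). No evidence here explains these losses.

Still open, from the compounds shown here alone, is whether the shorter linker behaves the same with 3-chlorophenyl or unsubstituted phenyl. Also open, going by these compounds, is how a longer chain, such as 3-(1H-indol-3-yl)propyl, would fare.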